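Changing the Group Between the Two Ring Oxygens

This account rests on a few compounds, and the source may have more. Where it says the series, first, only, none or still open, it means among the compounds named here.

Compound 1, `N#Cc1ccc(C2OCC(C/C=C\CCC(=O)O)C(c3cccnc3)O2)cc1`, gives 1290 nM in a functional assay for inhibition, with Homo sapiens as the target; on this read-out lower numbers stand for tighter binding and higher numbers for weaker binding.
Compound 2, `O=C(O)CC/C=C\CC1COC(c2ccc(C(F)(F)F)cc2)OC1c1cccnc1`, gives 1780 nM in this assay.
Compound 3, `O=C(O)CC/C=C\CC1COC(c2ccsc2)OC1c1cccnc1`, gives 1580 nM in this assay.

These three numbers lie close together. Compound 3 stands second of the three, but its nearest neighbour is compound 2 with a 1.1-fold lower number from compound 2 to compound 3 (0.05 log units; within the scatter), and its furthest is compound 1 with a 1.2-fold higher number from compound 1 to compound 3 (0.09 log units; within the scatter); both steps are within the scatter, so compound 3 can be set neither above nor below the others. The remaining step, a 1.4-fold higher number from compound 1 to compound 2 (0.14 log units; within the scatter), is within the scatter as well.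

Compound 4, `CC(C)(Sc1ccccc1)C1OCC(C/C=C\CCC(=O)O)C(c2cccnc2)O1`, has not yet been measured. It differs from compound 3 in one place: a group of 10 heavy atoms (9 carbon, 1 sulfur; one six-membered aromatic ring of carbon only) in place of a group of 5 heavy atoms (4 carbon, 1 sulfur; one five-membered aromatic ring with 1 hetero atom), on a saturated ring carbon. The two steps that bear on this change are the ones that also exchanged the group on the same saturated ring carbon, between two ring oxygen atoms: the step from compound 1 to compound 3 and the step from compound 2 to compound 3. Both were within the scatter, so in this assay this position has so far accepted different groups without a change beyond the scatter. The group entering compound 4 is larger than any tried so far, which the measured steps do not cover, so the expectation is held with some caution.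

For compound 4 a step within the scatter is expected, namely a 1.1-fold lower number from compound 3 to compound 4 (0.02 log units; within the scatter). The estimate for compound 4 is 1500 nM, with a range from 500 nM to 4500 nM.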

Compound 4, dissociation constant: 200 nM
The estimate for compound 4 lay 7.5-fold (0.88 log units) above the measured number; measured number outside the range, below it.
By their numbers in this assay, from the lowest: compound 4; then compounds 1, 3 and 2 (each within the scatter of the next).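

In this assay, among these compounds, the saturated ring carbon between two ring oxygen atoms proves less forgiving than the earlier compounds suggested: the group of 10 heavy atoms entering here gives a 7.9-fold lower number from compound 3 to compound 4 (0.90 log units; beyond the scatter). The same holds against the other two groups, with a 6.5-fold lower number from compound 1 to compound 4 (0.81 log units; beyond the scatter) and an 8.9-fold lower number from compound 2 to compound 4 (0.95 log units; beyond the scatter), so the three earlier groups, which could not be told apart, all stand on the same side of this change. Heavy-atom count alone does not settle the matter, since the 4-(trifluoromethyl)phenyl group of compound 2 also has 10 heavy atoms and a six-membered aromatic ring of carbon only, yet compound 4 stands clearly apart from it.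

Nothing available here offers a measured explanation for this lower number. Also open, as far as these compounds go, is which part of the entering group matters, for instance whether a version with oxygen in place of its sulfur, or a plain benzyl group on the same ring carbon, would keep the number this low in this assay.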